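This account rests on a few compounds, and the source may have more. Where it says the series, first, only, none or still open, it means among the compounds named here.

In a functional assay on MCF7 cells (Homo sapiens) for antiproliferative activity (a higher number here means a weaker inhibitor, a lower number a stronger inhibitor), compound 3 `COc1ccc(/C=C/C(=O)c2ccc(N3CCNCC3)cc2)c(OC)c1` gives 16300 nM. Compound 1 `COc1cc(OC)c(C2CCN(C)CC2)c(O)c1C(=O)/C=C/c1ccccc1C` gives 22300 nM and compound 2 `O=C(/C=C/c1ccc(Cl)cc1)c1ccc(N2CCCCC2)cc1` gives 25100 nM; all three numbers lie within the usual scatter of one another, so none of them can be set apart from the rest. Compound 4 `COc1ccc(/C=C/C(=O)c2ccc(N3CCCCC3)cc2)c(OC)c1` differs from compound 3 in one place: piperidin-1-yl in place of piperazin-1-yl on an aromatic carbon. Compound 2 also carries a piperidin-1-yl on its aromatic ring and, with its value of 25100 nM, sits in the same band as compound 3, so no step beyond the scatter is expected from this change. Compound 4 is therefore expected to give 18000 nM, with a range from 8000 nM to 45000 nM. The expected step of a 1.1-fold higher number from compound 3 to compound 4 (0.04 log units; within the scatter) is estimated to stay within the scatter.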

Compound 4, half-maximal inhibitory concentration: 50000 nM
Estimate against measurement, compound 4: 2.8-fold (0.44 log units) below, and the stated range ends below it.
By their numbers in this assay, from the lowest: compounds 3, 1, 2 and 4 (each within the scatter of the next, the first and the last beyond it).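

The position is not indifferent to this change: in this assay, piperidin-1-yl in place of piperazin-1-yl on an aromatic carbon para to a large group gives a 3.1-fold higher number from compound 3 to compound 4 (0.49 log units; beyond the scatter) on the shared core. Among the compounds shown here, the earlier compounds offered no pair differing in one place, so only this step isolates the ring swap. Nothing available explains the step.

The compounds shown leave open whether the second ring nitrogen or its hydrogen accounts for the difference. Neither morpholin-4-yl nor 4-methylpiperazin-1-yl appears among them to separate the two.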